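A few compounds are considered here, and "the series" means these few. Any claim that something is new, unique, unknown or untested is made for them only; others in the source may bear on it.

Series notes. Compound 1 `NC(=O)c1nn(C2O[C@H](CO)[C@@H](O)[C@H]2O)cc1[N+](=O)[O-]` is measured in a functional assay on L1210 cells (Mus musculus); a higher number here means a weaker inhibitor, a lower number a stronger inhibitor; the value for compound 1 is only a limit of the measurement, > 1730 uM. Compound 2 `Cc1c([N+](=O)[O-])c(C(N)=O)nn1C1O[C@H](CO)[C@@H](O)[C@H]1O` carries methyl in place of hydrogen on an aromatic carbon of the shared core. In this assay compound 2 likewise reaches only a limit, > 1650 uM. The step that the two limits leave unreadable from compound 1 to compound 2 cannot be read because both values sit at limits (the limit of > 1650 uM in this assay, at which 1 of the 2 values shown sits, (the limit of > 1730 uM in this assay, at which 1 of the 2 values shown sits)). Compound 2 thus stands at a limit, with no number beneath it. Compound 3 `Cc1c(N)c(C(N)=O)nn1C1O[C@H](CO)[C@@H](O)[C@H]1O` is not yet measured; it differs from compound 2 by amino in place of nitro on an aromatic carbon. Among the measured compounds shown here, no measured step touches this exchange, and the one step in hand is unreadable, so neither direction nor size of the move to compound 3 can be taken from the data. For compound 3 the expected step of an at least 1.1-fold lower number from compound 2 to compound 3 (0.04 log units; that floor lies within the scatter) is set close to none, a limit being the likeliest outcome. The value expected for compound 3 in this assay is 1500 uM, within 300 uM to 5000 uM.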

Compound 3, concentration for 50% inhibition: > 1840 uM
Compound 3 ended at the assay's limit; the forecaster's own chance of this, stated with the estimate: 70%; middle value at least 1.2-fold (0.08 log units) away from the limit.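

Compound 3 reaches only a limit in this assay, > 1840 uM. Compound 2 is likewise only a limit, > 1650 uM, so the step between compound 2 and compound 3 cannot be read. The compounds shown leave open what amino in place of nitro does to a measurable value in this assay.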